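The compounds below may be only part of what the source reports. "The series", "measured", "known", "first", "only" and "open" are said of these compounds alone.

Working notes on the series, taken in a functional assay on B16-F0 cells (Mus musculus) for inhibition, read by CCK-8 assay, with a stated time of 48 h; a lower number here means a stronger inhibitor, a higher number a weaker inhibitor.

Of the compounds shown here, three have numbers so far. Compound 1, `COc1ccc(-c2cc3nccc(-c4cc(OC)c(OC)c(OC)c4)n3n2)cc1N`, gives 88 nM. Compound 2, `COc1cc(-c2ccnc3cc(-c4ccc5cc[nH]c5c4)nn23)cc(OC)c1OC`, gives 55 nM. Compound 3, `COc1ccc(-c2cc3nccc(-c4cc(OC)c(OC)c(OC)c4)n3n2)cc1F`, gives 3950 nM, the highest of the three. Its nearest neighbour by number is compound 1, reached by a 45-fold higher number from compound 1 to compound 3 (1.65 log units; beyond the scatter); the furthest is compound 2, reached by a 72-fold higher number from compound 2 to compound 3 (1.86 log units; beyond the scatter). Both steps that lead into compound 3 are large and in the same direction, so the 3-fluoro-4-methoxyphenyl group marks the weak end of what has been measured.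

Compound 4, `COc1cc(-c2ccnc3cc(-c4ccc(N(C)C)cc4)nn23)cc(OC)c1OC`, is the next structure to be placed. It differs from compound 3 in one place: 4-(dimethylamino)phenyl in place of 3-fluoro-4-methoxyphenyl on an aromatic carbon. The group that enters carries a nitrogen on the ring, as does the 3-amino-4-methoxyphenyl of compound 1, whereas the group that leaves is the one shared by nothing else in the set. Among the measured compounds shown here, the two measured steps that bear on the change both say that leaving this group lowers the number by a large amount, and no step says otherwise. For the measured compounds named here, a large step downward, back toward the region of compounds 1 and 2, is therefore expected, though the 4-(dimethylamino)phenyl itself has no measured precedent here, so the range is kept wide.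

For compound 4 the estimate is 100 nM, from 30 nM to 400 nM, which would mean a 40-fold lower number from compound 3 to compound 4 (1.60 log units; beyond the scatter).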

Compound 4, half-maximal inhibitory concentration: 702 nM
Compound 4: middle estimate off by 7.0-fold (0.85 log units), on the low side; measured number outside the range, above it.
By their numbers in this assay, from the lowest: compounds 2 and 1 (each within the scatter of the next); then compound 4; then compound 3.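

In this assay, leaving the 3-fluoro-4-methoxyphenyl group does not by itself restore the low numbers of compounds 1 and 2: the gain is only a 5.6-fold lower number from compound 3 to compound 4 (0.75 log units; beyond the scatter), and the 4-(dimethylamino)phenyl group settles between the two ends of the series. The identity of the entering group therefore matters at this position, on an aromatic carbon of the five-membered ring, as shown by a 13-fold higher number from compound 2 to compound 4 (1.11 log units; beyond the scatter) and an 8.0-fold higher number from compound 1 to compound 4 (0.90 log units; beyond the scatter), and a nitrogen on the phenyl ring is not enough to match compound 1. No measurement on hand explains the gap between these groups.

Among these compounds, the 1H-indol-6-yl and 3-amino-4-methoxyphenyl groups each carry a hydrogen on nitrogen and the 4-(dimethylamino)phenyl group does not, but it remains open whether that difference separates them, and a methylamino group in place of the dimethylamino group would test it. Also open, on these data alone, is whether a hydroxyl group on the phenyl ring would give numbers like those of compounds 1 and 2, or whether the low numbers are confined to nitrogen-bearing groups.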